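Working notes: swapping the group on the pendant phenyl ring

The source may hold more compounds than are shown below. What is called first, only, known or untested is meant among the compounds shown, and "the series" means these compounds.

Measured so far:
compound 1 `C/C(=C\c1cc(-c2ccc(F)cc2)cs1)C(N)=O` — > 50000 nM
compound 2 `C/C(=C\c1cc(-c2ccc(S(C)(=O)=O)cc2)cs1)C(N)=O` — > 50000 nM

In a functional assay on A549 cells (Homo sapiens) for cytotoxicity, read by CCK-8 assay, with a stated time of 24 h (a lower number here means a stronger inhibitor, a higher number a weaker inhibitor), compound 1 reaches only a limit of the assay, > 50000 nM, not a number. In this assay compound 2 likewise sits at a limit, > 50000 nM. Going by the values given here, the single measured step, a step that the two limits leave unreadable from compound 1 to compound 2, is therefore unreadable because both values rest at the limit of > 50000 nM in this assay, at which 2 of the 2 values shown sit. Where compound 2 stands can only be said as a limit, with no number to place it on the scale.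

Compound 3 `C/C(=C\c1cc(-c2ccc([N+](=O)[O-])cc2)cs1)C(N)=O` differs from compound 2 by nitro in place of methylsulfonyl on an aromatic carbon. Among the compounds with values here, no measured step bears on this change beyond the unreadable one, and both compounds made so far stay at the limit. For this assay compound 3 is expected to remain at or near that limit, an estimate of 80000 nM with a range from 30000 nM to 300000 nM. This estimate corresponds to a step that the limit leaves unreadable from compound 2 to compound 3, none beyond the scatter.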

Compound 3, half-maximal inhibitory concentration: 3500 nM
For compound 3 the middle estimate is 23-fold (1.36 log units) above the measured one; the whole stated range lies above it.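

In this assay, going by these compounds alone, nitro in place of methylsulfonyl on the aromatic carbon para to a large group gives an at least 14-fold lower number from compound 2 to compound 3 (1.15 log units; beyond the scatter), the first readable step. Nitro in place of fluoro at the same carbon gives an at least 14-fold lower number from compound 1 to compound 3 (1.15 log units; beyond the scatter), so the group at this position can bring the read-out off the limit, which neither of the other two groups does. Compound 3 is the only compound here with a number, while compound 1 and compound 2 remain limits and not numbers: the limit of > 50000 nM in this assay, at which 2 of the 3 values shown sit.

The step between compound 1 and compound 2 cannot be read, so fluoro and methylsulfonyl cannot be ordered against each other. Whether the effect is confined to nitro stays open, as the compounds shown do not include an amine, a nitrile or a carboxylic acid at this carbon.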